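Amide replacement on compound 2, step from 2 to 3

This account rests on a few compounds, and the source may have more. Where it says the series, first, only, none or still open, it means among the compounds named here.

Compound 2 `COc1cc(Cl)cc(-c2nn(-c3cccc(NC(=O)Nc4ccc(Cl)c(Cl)c4)c3)cc2-c2ccncc2)c1` and compound 1 `O=C(Nc1cccc(-n2cc(-c3ccncc3)c(-c3cc(O)cc(Cl)c3)n2)c1)Nc1ccc(Cl)c(Cl)c1` are the only measured points in a functional assay on SK-MEL-28 cells (Homo sapiens) for inhibition, read by sulforhodamine B assay, with a stated time of 48 h, tested at 0.01 uM; a higher number here means a weaker effect of the compound at the concentration tested, a lower number a stronger effect. Compound 2 gives 101%, and compound 1 gives 108%; the two numbers lie within the scatter of each other, and both mean no measurable inhibition at this concentration. Among the compounds with values here, the single measured step, a number 7 percentage points lower from compound 1 to compound 2 (within the scatter), concerns the methyl on the oxygen and is itself within the scatter.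

Compound 3 `COc1cc(Cl)cc(-c2nn(-c3cccc(NC(=O)c4cccc(C(F)(F)F)c4)c3)cc2-c2ccncc2)c1` differs from compound 2 at the carbonyl carbon: 3-(trifluoromethyl)phenyl in place of (3,4-dichlorophenyl)amino on a carbonyl carbon. Within the data shown here, no measured step touches this part of the structure, so the step from compound 1 to compound 2 gives no direct guidance. The expected step is a number 1 percentage points lower from compound 2 to compound 3 (within the scatter), meaning no movement beyond the scatter, because compound 2 gives 101% and nothing measured suggests this concentration reveals an effect. Compound 3 is estimated at 100%, range 85% to 115%.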

Compound 3, a percentage reported as activity, at one concentration (the size of the read-out at that concentration, not a potency): 105%
Compound 3: middle estimate off by 5 percentage points, on the low side; the measured number falls inside the stated range.
By their numbers in this assay, from the lowest: compounds 2, 3 and 1 (each within the scatter of the next).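

In this assay, within the data shown here, 3-(trifluoromethyl)phenyl in place of (3,4-dichlorophenyl)amino on a carbonyl carbon gives a number 4 percentage points higher from compound 2 to compound 3 (within the scatter), the first reading at this position of the series. The change removes the hydrogen-bond donor counted on the leaving group and replaces both chlorine atoms with the fluorine atoms of trifluoromethyl, yet compound 3 at 105% still shows no measurable inhibition at this concentration. Nothing available explains this flat read-out.

As far as these compounds go, with all three compounds showing no measurable inhibition, this single concentration cannot separate the two groups, so any difference between them at higher concentrations stays open. Also open, from the compounds shown here alone, is whether a quite different group on this carbonyl carbon, such as cyclohexyl or a phenyl ring carrying a carboxylic acid, would move the read-out beyond the scatter.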